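A few compounds are considered here, and "the series" means these few. Any claim that something is new, unique, unknown or untested is made for them only; others in the source may bear on it.

Working notes on the enaminone series in a functional assay on MDA-MB-231 cells (Homo sapiens) for antiproliferative activity, read by sulforhodamine B assay, with a stated time of 48 h; a higher number here means a weaker inhibitor, a lower number a stronger inhibitor.

Two cores are in hand. Compound 1 `COc1ccc(C(=O)/C=C\Nc2ccc(-c3nc4cc(OC)c(OC)c(OC)c4s3)cc2C)cc1O` gives 12400 nM in this assay, and compound 3 `COc1ccc(C(=O)/C=C\Nc2ccc(-c3nc4cc(OC)c(OC)c(OC)c4s3)cc2C)cc1F` gives 2900 nM. The step between them, (fluoro in place of hydroxy on an aromatic carbon), reads a 4.3-fold lower number from compound 1 to compound 3 (0.63 log units; beyond the scatter). Compound 2 `COc1ccc2nc(-c3ccc(N/C=C\C(=O)c4ccc(OC)c(O)c4)c(C)c3)sc2c1` carries the other core and gives 14000 nM in this assay; the difference between the core of compound 2 and the core of compound 1 is not broken down here. The values of compound 1 and compound 2 lie within the scatter of one another, while compound 3 sits beyond the scatter from both.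

Compound 4 `COc1ccc2nc(-c3ccc(N/C=C\C(=O)c4ccc(OC)c(F)c4)c(C)c3)sc2c1` is not yet measured. It differs from compound 2 by fluoro in place of hydroxy on an aromatic carbon, the same change that turned compound 1 into compound 3, at the same kind of place. Going by the values given here, the expectation for compound 4 rests on compound 3, because a 4.3-fold lower number from compound 1 to compound 3 (0.63 log units; beyond the scatter) is the only measured instance of this change, and the step is expected to repeat on the second core at about a 3.7-fold lower number from compound 2 to compound 4 (0.57 log units; beyond the scatter). Compound 4 is therefore estimated at 3800 nM in this assay, with a plausible range from 1900 nM to 7600 nM.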

Compound 4, half-maximal inhibitory concentration: 2000 nM
For compound 4 the middle estimate is 1.9-fold (0.28 log units) above the measured one; low and high end bracket the measured number.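

In this assay the replacement of hydroxy by fluoro on the second core gives a 7.0-fold lower number from compound 2 to compound 4 (0.85 log units; beyond the scatter) and so runs the same way as on the first core. The two steps do not differ in size beyond what repeated measurement allows: the same change on two cores in this assay, a 4.3-fold lower number (0.63 log units; beyond the scatter) from compound 1 to compound 3 and a 7.0-fold lower number (0.85 log units; beyond the scatter) from compound 2 to compound 4, 1.6-fold (0.21 log units) apart, within the scatter of two such steps. The 3-hydroxy-4-methoxyphenyl to 3-fluoro-4-methoxyphenyl change therefore carried over between these two cores, but this rests on one pair per core, and it shows neither why the number drops nor that a further core would follow.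

The compounds shown leave open whether other groups in the place of the hydroxy, such as an amine, a chloro group or a nitrile, would give a similar step on either core. They also leave open whether the step would hold if the neighbouring methoxy group gave way to a longer chain such as ethoxy or propoxy.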